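The source may hold more compounds than are shown below. What is called first, only, known or untested is meant among the compounds shown, and "the series" means these compounds.

Measured so far:
- compound 1 `COc1ccc([C@@H]2C/C(=N/OCc3cn(-c4ccc(C(=O)c5ccccc5)cc4)nn3)c3cc(CC=C(C)C)c(OC)cc3O2)cc1`: 41%
- compound 2 `C#CCOc1ccc([C@@H]2CC(=O)c3cc(CC=C(C)C)c(OC)cc3O2)cc1`: 68%

In a functional assay on MCF7 cells (Homo sapiens) for inhibition, read by sulforhodamine B assay, with a stated time of 48 h, tested at 50 uM (a lower number here means less inhibition of growth, a higher number more inhibition of growth at the concentration tested), compound 1 gives 41%, the lower of the two numbers. Compound 2 reaches 68%, and the gap between the two lies beyond the usual scatter. Only these two values are available, and they do not form a single-place step, so the series offers no measured guide to the next change.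

The next compound to be measured is compound 3 `COc1ccc([C@@H]2C/C(=N/OCc3cn(-c4ccc(NC(=O)c5ccccc5)cc4)nn3)c3cc(CC=C(C)C)c(OC)cc3O2)cc1`. It departs from compound 1 at one place: benzamido in place of benzoyl on an aromatic carbon. In words, benzamido stands in place of benzoyl on an aromatic carbon, para to a large group, and the rest of the structure is unchanged.

Among the measured compounds shown here, with no measured precedent for this swap, the working expectation in this assay is no step beyond the scatter, in neither direction. The anchor for this expectation is compound 1 at 41%. The estimated move is small: a number 1 percentage points higher from compound 1 to compound 3 (within the scatter). For compound 3 the expected value is 42%, with an estimated range of 24% to 60%.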

Compound 3, percent growth inhibition at one concentration: 4%
Compound 3: the middle estimate sits 38 percentage points above what was measured; measured number below the stated range.
By their numbers in this assay, from the lowest: compound 3; then compound 1; then compound 2.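

In this assay, among the compounds shown here, the aromatic carbon para to a large group is the first place with a readable single-place step, and it is not tolerant of every change: benzamido in place of benzoyl gives a number 37 percentage points lower from compound 1 to compound 3 (beyond the scatter), a large step beyond the scatter. The two groups share a six-membered aromatic ring of carbon only and a double bond outside aromatic rings, and benzamido adds a nitrogen and a hydrogen-bond donor, so a change limited to the link to that ring is enough to produce a step of this size. No measurement available here bears on why the step occurs.

This single step cannot separate the contribution of the amide hydrogen from that of the added nitrogen, and a benzamido group carrying a methyl on its nitrogen, or a phenoxy group in the same place, would help to pull these apart. Also open, as far as these compounds go, is how an amine or a carboxylic acid at this aromatic carbon would read, and whether the step carries over to other changes on the core.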